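The source may hold more compounds than are shown below. What is called first, only, known or untested is meant among the compounds shown, and "the series" means these compounds.

Of the compounds shown here, three sharing one core have been measured in a functional assay on CHO-K1 cells for antagonist activity at adenosine receptor A1 (Homo sapiens), read by a beta-galactosidase reporter and cAMP accumulation, with stated times of 15 min and 6 h; a higher number here means a weaker inhibitor, a lower number a stronger inhibitor. Compound 1 `Nc1nc(-c2ccc(C(F)F)o2)nc2sc(Cc3ccccc3)cc12` gives 3000 nM. Compound 2 `COc1ccccc1Cc1cc2c(N)nc(-c3ccc(C(F)F)o3)nc2s1`, which carries a methoxy in place of hydrogen on an aromatic carbon, gives 516 nM in this assay, a step of a 5.8-fold lower number from compound 1 to compound 2 (0.76 log units; beyond the scatter). Compound 3 `Cc1nc(-c2nc(N)c3cc(Cc4ccccc4)sc3n2)cs1` gives 263 nM, a step of an 11-fold lower number from compound 1 to compound 3 (1.06 log units; beyond the scatter). Among these three numbers compound 2 stands second highest: compound 3 lies within the scatter of it, while compound 1 lies beyond it.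

Compound 4 `COc1ccccc1Cc1cc2c(N)nc(-c3cccc(C#N)c3)nc2s1` has not yet been measured. It differs from compound 2 by 3-cyanophenyl in place of 5-(difluoromethyl)furan-2-yl on an aromatic carbon. Among the measured compounds shown here, only one measured step touches this position: an 11-fold lower number from compound 1 to compound 3 (1.06 log units; beyond the scatter) shows that exchanging the 5-(difluoromethyl)furan-2-yl for another ring brought a large gain there. The group entering compound 4, a 3-cyanophenyl, is a six-membered ring of carbon only with a triple bond outside the ring rather than a five-membered ring with one hetero atom, so that step is only a loose guide. The expectation in this assay is a step of a 2.3-fold lower number from compound 2 to compound 4 (0.37 log units; beyond the scatter), a lowering beyond the scatter but smaller than the earlier large one. Compound 4 is therefore estimated at 220 nM, with an expected range from 60 nM to 800 nM.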

Compound 4, inhibition constant: 129 nM
Beside the measured number, compound 4's estimate is 1.7-fold (0.23 log units) above it; the range from low to high includes it.
By their numbers in this assay, from the lowest: compound 4; then compounds 3 and 2 (each within the scatter of the next); then compound 1.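

In this assay, the position on the aromatic carbon between two ring nitrogen atoms now shows a second replacement of the 5-(difluoromethyl)furan-2-yl that lowers the number, a 4.0-fold lower number from compound 2 to compound 4 (0.60 log units; beyond the scatter). Among the compounds shown here, until now the only step read at this position led to a five-membered ring, on a core without the methoxy; this one shows that a six-membered aromatic ring of carbon only, carrying a nitrile, is also accepted there, and that a lowering at this position also occurs with the methoxy in place. The two groups exchanged here match in heavy atoms, hydrogen-bond donors and hydrogen-bond acceptors, so these counts do not separate them, and the change lies in the ring and its triple bond.

The compounds shown leave open whether the nitrile has any part in this step, since no plain phenyl stands beside compound 4, and whether an amine or a carboxylic acid in its place would give a similar number. They also do not show how the 2-methyl-1,3-thiazol-4-yl would behave with the methoxy present, and no available evidence explains the step.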